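A few compounds are considered here, and "the series" means these few. Any claim that something is new, unique, unknown or untested is made for them only; others in the source may bear on it.

Measured compounds in a functional assay on RS4-11 cells (Homo sapiens) for inhibition, read by CCK-8 assay, with a stated time of 48 h, tested at 20 uM; a higher number here means more inhibition of growth at the concentration tested, a lower number less inhibition of growth:

Compound 1, `Cc1ccc(S(=O)(=O)Oc2ccccc2/C=C(\C#N)C(=O)Nc2nnc(Cc3cccc4ccccc34)s2)cc1` — 73%
Compound 2, `COc1ccc(S(=O)(=O)Oc2ccccc2/C=C(\C#N)C(=O)Nc2nnc(Cc3cccc4ccccc34)s2)cc1` — 78%
Compound 3, `Cc1ccc(S(=O)(=O)Oc2ccccc2/C=C(\C#N)C(=O)Nc2nnc(Cc3ccccc3)s2)cc1` — 69%

Compound 1 and compound 2 share one core; compound 2 carries methoxy in place of methyl on an aromatic carbon. In this assay the change gives a number 5 percentage points higher from compound 1 to compound 2 (within the scatter). Compound 3 differs from compound 1 by phenyl in place of naphthalen-1-yl on a saturated chain carbon bound to an aromatic carbon, and that change gives a number 4 percentage points lower from compound 1 to compound 3 (within the scatter). All three values sit close to one another.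

Compound 4, `COc1ccc(S(=O)(=O)Oc2ccccc2/C=C(\C#N)C(=O)Nc2nnc(Cc3ccccc3)s2)cc1`, is not yet measured. It stands to compound 3 as compound 2 stands to compound 1: methoxy in place of methyl on an aromatic carbon. The place line reads the same in both cases, so this is the same change, made on the core of compound 3 rather than that of compound 1. Since compound 1 to compound 2 moved only within the scatter, the step from compound 3 to compound 4 is expected to be about a number 5 percentage points higher from compound 3 to compound 4 (within the scatter), a comparable small shift. On that basis compound 4 is estimated at 74%, with an expected range from 64% to 84%.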

Compound 4, percent growth inhibition at one concentration: 78%
Compound 4: the middle estimate sits 4 percentage points below what was measured, within the range that was stated.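

In this assay, the change from 4-methylphenyl to 4-methoxyphenyl gives a number 9 percentage points higher from compound 3 to compound 4 (within the scatter), and the two cores show no difference beyond what repeat measurements would allow: the same change on two cores in this assay, a number 5 percentage points higher (within the scatter) from compound 1 to compound 2 and a number 9 percentage points higher (within the scatter) from compound 3 to compound 4, 4 percentage points apart, within the scatter of two such steps. Phenyl in place of naphthalen-1-yl gives no change at the digits printed from compound 2 to compound 4 (within the scatter), and this change also reads alike on both cores: the same change on two cores in this assay, a number 4 percentage points lower (within the scatter) from compound 1 to compound 3 and no change at the digits printed (within the scatter) from compound 2 to compound 4, 4 percentage points apart, within the scatter of two such steps. Among these four compounds, neither change visibly depends on the core, but every step lies within the scatter, so neither change is shown to alter growth inhibition, and the agreement between cores is no proof that the effects add up in a predictable way.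

The compounds shown leave open whether a step beyond the scatter would appear with an amine or a carboxylic acid in place of the methyl, or with a saturated ring such as cyclohexyl in place of the phenyl. With only one tested concentration, they also leave open how the four compounds would compare at lower concentrations.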